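This account rests on a few compounds, and the source may have more. Where it says the series, first, only, none or still open, it means among the compounds named here.

Three compounds share one core and differ only in the group carried on the sulfonamide nitrogen. Compound 1 `O=C1NCCN1c1ccc(S(=O)(=O)Nc2ccc(OC(F)F)cc2)cc1` gives 410 nM in a functional assay on M21 cells (Homo sapiens) for antiproliferative activity, read by sulforhodamine B assay, with a stated time of 48 h; on this read-out higher numbers stand for weaker inhibition and lower numbers for stronger inhibition. Compound 2 `CC(C)Cc1ccc(NS(=O)(=O)c2ccc(N3CCNC3=O)cc2)cc1` reaches only the limit of > 1000 nM in this assay, which is not a number but the edge of what this assay reports (the limit of > 1000 nM in this assay, at which 1 of the 3 values shown sits). Compound 3 `COc1ccccc1NS(=O)(=O)c1ccc(N2CCNC2=O)cc1` gives 300 nM in this assay, the lowest of the two numbers shown, and compound 1 sits within the scatter of it, so the two cannot be ordered.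

Compound 4 `Cc1cccc(NS(=O)(=O)c2ccc(N3CCNC3=O)cc2)c1` is compound 3 with a change on the same aryl group: 3-methylphenyl in place of 2-methoxyphenyl on a sulfonamide nitrogen. For the measured compounds named here, the only measured step, an at least 2.4-fold higher number from compound 1 to compound 2 (0.38 log units; beyond the scatter), concerns a different group and gives no direct guide; it only shows that a change on this aryl group can weaken the effect. Going by the values given here, with one step of unrelated kind and no step at the same position, the change to compound 4 is expected to sit near the scatter, at most a slight weakening, as a 1.5-fold higher number from compound 3 to compound 4 (0.18 log units; within the scatter). Compound 4 is therefore estimated at 450 nM in this assay, within 150 nM to 1500 nM.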

Compound 4, half-maximal inhibitory concentration: 69 nM
Compound 4: the middle estimate sits 6.5-fold (0.81 log units) above what was measured, and the stated range ends above it.
By their numbers in this assay, from the lowest: compound 4; then compounds 3 and 1 (each within the scatter of the next). At a limit, above all of these: compound 2.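

In this assay, the group on the sulfonamide nitrogen can strengthen the effect as well as weaken it: 3-methylphenyl in place of 2-methoxyphenyl gives a 4.3-fold lower number from compound 3 to compound 4 (0.64 log units; beyond the scatter). The earlier step on this aryl group pointed only towards weaker inhibition, so this position now responds in both directions, and a modest change of substituent is enough to move the number beyond the scatter. The two groups differ in more than one respect, including the hydrogen-bond acceptor counted in 2-methoxyphenyl but not in 3-methylphenyl, and nothing measured here explains the gain.

The compounds shown leave open which of those differences carries the step. They also leave open how this aryl group would fare with an amine, a carboxylic acid or a longer chain in place of the methyl.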